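A few compounds are considered here, and "the series" means these few. Any claim that something is new, unique, unknown or untested is made for them only; others in the source may bear on it.

Measured compounds in a functional assay on HeLa cells (Homo sapiens) for cytotoxicity, read by MTT assay, with a stated time of 48 h; a higher number here means a weaker inhibitor, a lower number a stronger inhibitor:
Compound 1 `Cc1ccc(S(=O)(=O)/N=C(/CCNC2=CC(=O)c3ccccc3C2=O)Nc2ccccc2[N+](=O)[O-])cc1` gives 3310 nM.
Compound 2 `Cc1ccc(S(=O)(=O)/N=C(/CCNC2=CC(=O)c3ccccc3C2=O)Nc2ccccc2I)cc1` gives 19100 nM.
Compound 3 `COc1ccc(N/C(CCNC2=CC(=O)c3ccccc3C2=O)=N\S(=O)(=O)c2ccc(C)cc2)c(OC)c1` gives 67600 nM.

Compound 2 stands second highest of the three: the step of a 5.8-fold higher number from compound 1 to compound 2 (0.76 log units; beyond the scatter) and the step of a 3.5-fold higher number from compound 2 to compound 3 (0.55 log units; beyond the scatter) both lie beyond the scatter. Compound 4 `Cc1ccc(S(=O)(=O)/N=C(/CCNC2=CC(=O)c3ccccc3C2=O)NCc2ccccc2)cc1` is not yet measured. It differs from compound 2 by benzyl in place of 2-iodophenyl on an amine nitrogen. Within the data shown here, no measured step swaps an aryl group for a benzyl group on this nitrogen; the steps of a 5.8-fold higher number from compound 1 to compound 2 (0.76 log units; beyond the scatter) and a 20-fold higher number from compound 1 to compound 3 (1.31 log units; beyond the scatter) only show that changing what sits on this nitrogen moves the number by modest to large amounts in either direction. With no closer guide, compound 4 is expected to stay near compound 2, a 1.3-fold lower number from compound 2 to compound 4 (0.10 log units; within the scatter), giving an estimate of 15000 nM with a range from 4000 nM to 60000 nM.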

Compound 4, half-maximal inhibitory concentration: 3980 nM
Estimate against measurement, compound 4: 3.8-fold (0.58 log units) above, outside the stated range (below it).
By their numbers in this assay, from the lowest: compounds 1 and 4 (each within the scatter of the next); then compound 2; then compound 3.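

Benzyl is the first group on this amine nitrogen that is not a substituted phenyl ring, and it gives a lower number than two of those rings (a 4.8-fold lower number from compound 2 to compound 4 (0.68 log units; beyond the scatter); a 17-fold lower number from compound 3 to compound 4 (1.23 log units; beyond the scatter)). Against the 2-nitrophenyl group, it makes no real difference (a 1.2-fold higher number from compound 1 to compound 4 (0.08 log units; within the scatter)), so a benzyl group without any substituent reaches the same level. Nothing measured here explains these shifts. Still open, going by these compounds, is whether a longer chain, such as phenylethyl, or a ring without aromatic character, such as cyclohexyl, would hold this level on the same nitrogen.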